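Alpha-Methyl Branching on the Benzylamine of Compound 3

The compounds below may be only part of what the source reports. "The series", "measured", "known", "first", "only" and "open" are said of these compounds alone.

Measured compounds in an assay on CHO cells for agonist activity at 5-hydroxytryptamine receptor 1D (Homo sapiens), read by GTPgammaS binding; on this read-out lower numbers stand for an effect already at smaller amounts and higher numbers for an effect only at larger amounts of compound:
compound 1 `O=S(=O)(NCC1CCN(CCCc2c[nH]c3ccc(-n4cnnc4)cc23)CC1)c1ccccc1`: 12 nM
compound 2 `c1ccc(CNCC2CCN(CCCc3c[nH]c4ccc(-n5cnnc5)cc34)CC2)cc1`: 5.6 nM
compound 3 `c1ccc(CNC2CCN(CCCc3c[nH]c4ccc(-n5cnnc5)cc34)CC2)cc1`: 7.6 nM

Compound 3 stands second highest of the three numbers, with compound 2 giving a number within the scatter of it and compound 1 likewise within the scatter. Compound 4 `C[C@H](NC1CCN(CCCc2c[nH]c3ccc(-n4cnnc4)cc23)CC1)c1ccccc1` carries methyl in place of hydrogen on a saturated chain carbon bound to an amine nitrogen and an aromatic carbon. Among the measured compounds shown here, no measured step alters this chain carbon, so none bears on the change directly; the nearest steps, a 1.6-fold lower number from compound 1 to compound 3 (0.20 log units; within the scatter) and a 1.4-fold higher number from compound 2 to compound 3 (0.13 log units; within the scatter), show that rearranging the amine side chain shifts the number little, while a 2.1-fold lower number from compound 1 to compound 2 (0.33 log units; beyond the scatter) is modest. Compound 4 is therefore expected to sit close to compound 3, with an expected step of a 1.1-fold higher number from compound 3 to compound 4 (0.02 log units; within the scatter), not beyond the scatter. The estimate for compound 4 is 8 nM, within 3 nM to 25 nM.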

Compound 4, half-maximal effective concentration: 12 nM
Beside the measured number, compound 4's estimate is 1.5-fold (0.18 log units) below it, and the stated range covers the measured number.
By their numbers in this assay, from the lowest: compounds 2, 3, 1 and 4 (each within the scatter of the next, the first and the last beyond it).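

In this assay methyl in place of hydrogen on this saturated chain carbon gives a 1.6-fold higher number from compound 3 to compound 4 (0.20 log units; within the scatter), so changing benzyl to 1-phenylethyl does not move the number past the scatter. Set against the other side chains, the same compound shows a 2.1-fold higher number from compound 2 to compound 4 (0.33 log units; beyond the scatter) and also no change at the digits printed from compound 1 to compound 4 (within the scatter). Nothing available explains these steps. Going by these compounds, how an ethyl group or a second methyl on this chain carbon would read remains open. So does the opposite configuration at this carbon.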